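Clearance of compound 2 and its unsaturated analogue

This account rests on a few compounds, and the source may have more. Where it says the series, first, only, none or still open, it means among the compounds named here.

Measured in an ADME assay on the whole organism (strain CD-1) for pharmacokinetics, with Mus musculus as the target, at a dose of 3 mg/kg by the intravenous route; on this read-out higher numbers stand for fast clearance and lower numbers for slow clearance:
- Compound 1 `O=C(O)CCCCCOc1ccccc1CN(C(=O)c1ccc(-c2ccco2)cc1)C1CC1`: 195 mL/min/kg
- Compound 2 `C[C@H](CCCOc1ccccc1CN(C)C(=O)c1ccc(-c2ccco2)cc1)CC(=O)O`: 0.3 mL/min/kg

Compound 2 holds the lower of the two numbers, and compound 1 lies far above it, well beyond the usual scatter of repeat measurements. Compound 3 `C/C(=C\C(=O)O)CCCOc1ccccc1CN(C)C(=O)c1ccc(-c2ccco2)cc1` has not yet been measured. It is compound 2 with a single change: 2-carboxy-1-methylethenyl in place of 1-(carboxymethyl)ethyl on a saturated chain carbon, three bonds along the chain from an oxygen on an aromatic ring. Here 2-carboxy-1-methylethenyl replaces 1-(carboxymethyl)ethyl on a saturated chain carbon, three bonds along the chain from an oxygen on an aromatic ring.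

Within the data shown here, no measured pair shows this change, so any forecast is uncertain. Among the measured compounds shown here, a rise in this assay is expected rather than a fall because compound 2 sits at 0.3 mL/min/kg, the lower of only two numbers. The expected step is small, near the edge of the scatter: a 2.3-fold higher number from compound 2 to compound 3 (0.37 log units; beyond the scatter). For compound 3 the estimate is 0.7 mL/min/kg, with an expected range of 0.15 mL/min/kg to 5 mL/min/kg.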

Compound 3, clearance: 11 mL/min/kg
Beside the measured number, compound 3's estimate is 16-fold (1.20 log units) below it; the whole stated range lies below it.
By their numbers in this assay, from the lowest: compound 2; then compound 3; then compound 1.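

In this assay, this position proves sensitive to a change that looks slight on paper: 2-carboxy-1-methylethenyl in place of 1-(carboxymethyl)ethyl gives a 37-fold higher number from compound 2 to compound 3 (1.56 log units; beyond the scatter) and so moves the number a long way. The two groups have the same 6 heavy atoms, with 1 hydrogen-bond donor and 1 hydrogen-bond acceptor each, yet the entering group has one more double bond outside aromatic rings and lacks the defined stereocentre. Nothing here accounts for the size of this step.

The double bond and the loss of the stereocentre arrive together, so the compounds shown cannot assign the step to either one. Going by these compounds, how a longer chain or a cyclopropyl group at this chain carbon would behave also remains open.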